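From Isopropyl to Methoxy: Expected Solubility of Compound 3

The compounds below may be only part of what the source reports. "The series", "measured", "known", "first", "only" and "open" are said of these compounds alone.

Of the compounds shown here, two sharing one core have been measured in a physicochemical assay for solubility, at pH 6.5; on this read-out lower numbers stand for lower solubility and higher numbers for higher solubility. Compound 1, `CCCS(=O)(=O)Nc1ccc(F)c(C(=O)Nc2cnc3[nH]nc(C(C)C)c3c2)c1F`, gives 6 ug/mL in this assay. Compound 2, `CC(C)CS(=O)(=O)Nc1ccc(F)c(C(=O)Nc2cnc3[nH]nc(C4CC4)c3c2)c1Cl`, gives 1 ug/mL. Compound 1 thus stands highest of the two numbers, and its distance to compound 2 lies beyond the usual scatter of this kind of measurement. Compound 3, `CCCS(=O)(=O)Nc1ccc(F)c(C(=O)Nc2cnc3[nH]nc(OC)c3c2)c1F`, has not been measured yet. It differs from compound 1 in one place: methoxy in place of isopropyl on an aromatic carbon. Going by the values given here, nothing measured so far isolates this single change, so no step between measured compounds can be borrowed for it. The step expected from this change is a 2.0-fold higher number from compound 1 to compound 3 (0.30 log units; within the scatter), a modest rise that may or may not clear the scatter. Compound 3 is therefore estimated at 12 ug/mL in this assay, with a range from 4 ug/mL to 40 ug/mL.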

Compound 3, solubility: 4 ug/mL
For compound 3 the middle estimate is 3.0-fold (0.48 log units) above the measured one, and the stated range covers the measured number.
By their numbers in this assay, from the lowest: compound 2; then compounds 3 and 1 (each within the scatter of the next).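

In this assay, going by these compounds alone, the pair isolates a single change for the first time: methoxy in place of isopropyl on an aromatic carbon gives a 1.5-fold lower number from compound 1 to compound 3 (0.18 log units; within the scatter). So at this carbon of the five-membered aromatic ring, an all-carbon group can give way to one holding an oxygen and a hydrogen-bond acceptor without the number moving beyond what repeat measurements would show. Compound 2 differs from compound 1 in more than one place, so this pair alone speaks directly to the position, and for these two groups it shows no measurable separation.

As far as these compounds go, whether an amine, a carboxylic acid or a longer chain on this same carbon would move the number beyond the scatter remains open. The data at hand offer no measured explanation for the size of this step.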